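Shifting a side chain across two related cores

A few compounds are considered here, and "the series" means these few. Any claim that something is new, unique, unknown or untested is made for them only; others in the source may bear on it.

Compound 2 `CC[C@H](C)[C@H](NC(=O)OC(C)(C)C)C(=O)N(Cc1ccccc1)C1(C(=O)NCc2ccccc2)CCN(Cc2ccccc2)CC1` and compound 1 `COC(=O)C[C@H](NC(=O)OC(C)(C)C)C(=O)N(Cc1ccccc1)C1(C(=O)NCc2ccccc2)CCN(Cc2ccccc2)CC1` share one core. In a functional assay on CCRF-CEM cells (Homo sapiens) for inhibition, with a stated time of 72 h (on this read-out lower numbers stand for stronger inhibition and higher numbers for weaker inhibition), compound 2 gives 7100 nM, while compound 1 gives 19000 nM. The change between them is (methoxycarbonyl)methyl in place of sec-butyl on a saturated chain carbon bound to an amide-type nitrogen and a carbonyl carbon and it produced a 2.7-fold higher number from compound 2 to compound 1 (0.43 log units; beyond the scatter).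

Compound 3 `CC[C@H](C)[C@H](NC(=O)OCc1ccccc1)C(=O)N(C1CC1)C1(C(=O)NCc2ccccc2)CCN(Cc2ccccc2)CC1` rests on a second core; how this core differs from that of compound 2 is not broken down here. In this assay compound 3 gives 16000 nM, which lies within the scatter of compound 1 and beyond the scatter of compound 2.

Compound 4 `COC(=O)C[C@H](NC(=O)OCc1ccccc1)C(=O)N(C1CC1)C1(C(=O)NCc2ccccc2)CCN(Cc2ccccc2)CC1` has not been measured. It differs from compound 3 by (methoxycarbonyl)methyl in place of sec-butyl on a saturated chain carbon bound to an amide-type nitrogen and a carbonyl carbon, the same change as from compound 2 to compound 1. For the measured compounds named here, since that change gave a 2.7-fold higher number from compound 2 to compound 1 (0.43 log units; beyond the scatter), a step of similar size is expected from compound 3, namely a 2.5-fold higher number from compound 3 to compound 4 (0.40 log units; beyond the scatter), though it is only one earlier instance on a different core. Compound 4 is therefore estimated at 40000 nM in this assay, with a likely range from 18000 nM to 90000 nM.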

Compound 4, half-maximal inhibitory concentration: 6200 nM
For compound 4 the middle estimate is 6.5-fold (0.81 log units) above the measured one; measured number below the stated range.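

On the core of compound 3, (methoxycarbonyl)methyl in place of sec-butyl gave a 2.6-fold lower number from compound 3 to compound 4 (0.41 log units; beyond the scatter) in this assay, so the change ran in the opposite direction to its earlier step on the core of compound 2. The outcome of this change in this series therefore depends on the core that carries it, and a step read on one core did not predict the direction on the other: the same change on two cores in this assay, a 2.7-fold higher number (0.43 log units; beyond the scatter) from compound 2 to compound 1 and a 2.6-fold lower number (0.41 log units; beyond the scatter) from compound 3 to compound 4, 6.9-fold (0.84 log units) apart, beyond the scatter of two such steps The result does not show which feature of the two cores turns the step around, and each direction rests on a single pair of compounds.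

The compounds shown leave open whether the reversal extends to other groups at this place, such as a carboxylic acid in place of the methyl ester or a longer chain in place of sec-butyl. They also leave open how the change would behave on a core that combines features of the two cores shown here.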